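Ring substituent change on a weakly cytotoxic scaffold

The source may report more compounds than this note shows. Statements on the series, on what has been measured and on what is new or still open speak of the compounds shown alone.

The compounds here share one core and differ only in the aromatic ring hanging from it. Compound 1 `C=CCn1c(=O)/c(=C\c2cccc(Cl)c2)[nH]c(=O)/c1=C\c1ccccc1OC` in a functional assay on NCI-H1975 cells (Homo sapiens) for cytotoxicity, read by CCK-8 assay, with a stated time of 72 h (on this read-out higher numbers stand for weaker inhibition and lower numbers for stronger inhibition), gives 5100 nM. Compound 2 `C=CCn1c(=O)/c(=C\c2cccc(Cl)c2Cl)[nH]c(=O)/c1=C\c1ccccc1OC` gives 4500 nM, and the step of a 1.1-fold lower number from compound 1 to compound 2 (0.05 log units; within the scatter) shows that adding a chloro in place of hydrogen on an aromatic carbon changed little. Compound 3 `C=CCn1c(=O)/c(=C\c2ccc(C)cc2)[nH]c(=O)/c1=C\c1ccccc1OC` is reported in this assay only as "not active" (no number reported), with no number, so it stands as the weakest-looking member, below what the assay could quantify. Compound 4 `C=CCn1c(=O)/c(=C\c2cc(F)ccc2C)[nH]c(=O)/c1=C\c1ccccc1OC` carries the change (5-fluoro-2-methylphenyl in place of 4-methylphenyl on a double-bonded chain carbon bound to an aromatic carbon), placing a 5-fluoro-2-methylphenyl where compound 3 holds a 4-methylphenyl. Among the measured compounds shown here, none of the measured steps covers this exchange; the single step that was measured, from compound 1 to compound 2, lay within the scatter and involved a different ring. With compound 3 giving no number and compounds 1 and 2 only weak, compound 4 is expected to remain weak, with an estimated value near 9000 nM and a plausible range from 3000 nM to 30000 nM.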

Compound 4, half-maximal inhibitory concentration: 7300 nM
Compound 4: the middle estimate sits 1.2-fold (0.09 log units) above what was measured, within the range that was stated.
By their numbers in this assay, from the lowest: compounds 2, 1 and 4 (each within the scatter of the next).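

In this assay compound 4 shows that a ring carrying a methyl group can still give a number at this place, on a double-bonded chain carbon bound to an aromatic carbon, while the step from compound 3 cannot be read because compound 3 has no number. Replacing 2,3-dichlorophenyl or 3-chlorophenyl with 5-fluoro-2-methylphenyl gives a 1.6-fold higher number from compound 2 to compound 4 (0.21 log units; within the scatter) and a 1.4-fold higher number from compound 1 to compound 4 (0.16 log units; within the scatter), so these three rings cannot be told apart here. Among these four compounds only compound 3, whose ring carries no halogen, lacks a number, and nothing available explains that difference.

Compound 4 alone cannot separate the contribution of the fluoro group from that of the methyl group. Going by these compounds, how a ring bearing an amine or a carboxylic acid would behave at this place remains open.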